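From Diethylamino to 4-Methylpiperidin-1-yl on a Shared Core

The compounds below may be only part of what the source reports. "The series", "measured", "known", "first", "only" and "open" are said of these compounds alone.

Of the compounds shown here, two built on a shared core have been measured so far. In a functional assay on A549 cells (Homo sapiens) for cytotoxicity, read by MTT assay, with a stated time of 72 h (on this read-out higher numbers stand for weaker inhibition and lower numbers for stronger inhibition), compound 1 (`CC1CCN(Cc2ccc3nc(NC(=O)N/N=C/c4cn(Cc5ccc(Cl)cc5Cl)c5ccccc45)sc3c2)CC1`) gives 3640 nM, and compound 2 (`CCN(CC)Cc1ccc2nc(NC(=O)N/N=C/c3cn(Cc4ccc(Cl)cc4)c4ccccc34)sc2c1`) gives 2940 nM. These two values lie within the scatter of each other, so compound 2 stands together with compound 1 on the numbers available. Compound 3 (`CC1CCN(Cc2ccc3nc(NC(=O)N/N=C/c4cn(Cc5ccc(Cl)cc5)c5ccccc45)sc3c2)CC1`) has not yet been measured. It departs from compound 2 in one place, with 4-methylpiperidin-1-yl in place of diethylamino on a saturated chain carbon bound to an aromatic carbon. Going by the values given here, no step between measured compounds isolates this change, so the data offer no direct guide to it. The 4-methylpiperidin-1-yl group does occur in compound 1, whose value of 3640 nM gives the only indirect hint. No step beyond the scatter, in either direction, is therefore expected in this assay. The estimate amounts to an expected step of a 1.1-fold higher number from compound 2 to compound 3 (0.04 log units; within the scatter). For compound 3 the estimated value is 3200 nM, with an expected range of 1400 nM to 7000 nM.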

Compound 3, half-maximal inhibitory concentration: 2030 nM
Beside the measured number, compound 3's estimate is 1.6-fold (0.20 log units) above it, within the range that was stated.
By their numbers in this assay, from the lowest: compounds 3, 2 and 1 (each within the scatter of the next).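

In this assay, the change from diethylamino to 4-methylpiperidin-1-yl on a saturated chain carbon bound to an aromatic carbon can now be read directly: it amounts to a 1.4-fold lower number from compound 2 to compound 3 (0.16 log units; within the scatter), so bringing in the six-membered non-aromatic ring and two more heavy atoms leaves the number within the scatter at this place. Compound 3 also gives the first comparison at a second place, where hydrogen in place of chloro on an aromatic carbon amounts to a 1.8-fold lower number from compound 1 to compound 3 (0.25 log units; within the scatter), and so neither single change shown separates its pair on this read-out. No evidence on the reason for these results is available.

The compounds shown leave open whether any group on this saturated chain carbon would produce a step beyond the scatter, for example a morpholine, a piperazine or a primary amine. They also leave open whether a fluoro or a methoxy group in place of the chloro would give a number that stands apart from those of compound 1 and compound 3.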